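A few compounds are considered here, and "the series" means these few. Any claim that something is new, unique, unknown or untested is made for them only; others in the source may bear on it.

Compound 1 `O=C(Nc1cccc(-c2oc3cc(-c4ccc(F)cc4)ccc3c(=O)c2O)c1)c1ccccc1F`: 17400 nM
Compound 2 `COc1ccc(C(=O)Nc2cccc(-c3oc4cc(-c5ccc(F)cc5)ccc4c(=O)c3O)c2)cc1`: 21100 nM
Compound 3 `O=C(Nc1cccc(-c2oc3cc(-c4ccc(F)cc4)ccc3c(=O)c2O)c1)c1ccc(Br)cc1`: 25400 nM

These three compounds share one core and differ only in the aromatic ring attached to the carbonyl carbon of the amide. In a functional assay on GTL 16 cells for antiproliferative activity against GTL 16 cell line (Homo sapiens), read by CCK-8 assay, with a stated time of 72 h (a higher number here means a weaker inhibitor, a lower number a stronger inhibitor), compound 1 gives 17400 nM, compound 2 gives 21100 nM and compound 3 gives 25400 nM. Among the measured compounds shown here, of the three numbers, the one for compound 3 is the highest, yet the step of a 1.2-fold higher number from compound 2 to compound 3 (0.08 log units; within the scatter) and the step of a 1.5-fold higher number from compound 1 to compound 3 (0.16 log units; within the scatter) are both within the usual scatter, so the three compounds cannot be separated on these data.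

Compound 4 `N#Cc1ccc(C(=O)Nc2cccc(-c3oc4cc(-c5ccc(F)cc5)ccc4c(=O)c3O)c2)cc1` is the next member of the same set. The change from compound 3 is cyano in place of bromo on an aromatic carbon. For the measured compounds named here, two measured steps bear on it. Both alter the same ring in the same way: a 1.5-fold higher number from compound 1 to compound 3 (0.16 log units; within the scatter) and a 1.2-fold higher number from compound 2 to compound 3 (0.08 log units; within the scatter), each within the scatter. Swapping one substituent on this ring for another has so far moved nothing beyond noise, and there is no reason in these numbers to expect otherwise here. The step of a 1.2-fold lower number from compound 3 to compound 4 (0.06 log units; within the scatter) is therefore expected to stay within the scatter. Compound 4 is estimated at 22000 nM, with a range from 11000 nM to 45000 nM.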

Compound 4, half-maximal inhibitory concentration: 31800 nM
Compound 4: middle estimate off by 1.4-fold (0.16 log units), on the low side; the measured number falls inside the stated range.
By their numbers in this assay, from the lowest: compounds 1, 2, 3 and 4 (each within the scatter of the next).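

Placing cyano where bromo stood adds a triple bond and a hydrogen-bond acceptor at this position, para to a large group, yet in this assay the change stays within the scatter (a 1.3-fold higher number from compound 3 to compound 4 (0.10 log units; within the scatter)). Cyano also cannot be told apart from methoxy at the same position (a 1.5-fold higher number from compound 2 to compound 4 (0.18 log units; within the scatter)), and even the widest gap in the set, which changes from the 2-fluorophenyl ring to the 4-cyanophenyl ring, remains within the scatter (a 1.8-fold higher number from compound 1 to compound 4 (0.26 log units; within the scatter)). This result extends the flat picture to a fourth aromatic ring on the amide carbonyl, and no separate measurement is available to explain it.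

Every compound shown carries a substituted phenyl ring on this carbonyl, so it remains open what an amine, a carboxylic acid or a longer chain on that ring would do. Going by these compounds, it is also open whether any change at this end of the molecule can move the number beyond the scatter, or whether a change elsewhere on the shared core would be needed.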